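This account rests on a few compounds, and the source may have more. Where it says the series, first, only, none or still open, it means among the compounds named here.

Measured compounds so far:
compound 1, `N#CC1=C(N)OC(c2c[nH]c3ccccc23)=C(C#N)C1c1ccc(Br)cc1`: 947 ug/mL
compound 2, `CN(C)c1ccc(C2C(C#N)=C(N)OC(c3c[nH]c4ccccc34)=C2C#N)cc1`: 900 ug/mL
compound 3, `COc1ccc(C2C(C#N)=C(N)OC(c3c[nH]c4ccccc34)=C2C#N)cc1`: 859 ug/mL

In a functional assay (a higher number here means a weaker inhibitor, a lower number a stronger inhibitor), compound 3 gives the lowest of the three numbers, but the steps of a 1.1-fold lower number from compound 1 to compound 3 (0.04 log units; within the scatter) and a 1.0-fold lower number from compound 2 to compound 3 (0.02 log units; within the scatter) are both within the scatter, so the three compounds cannot be set in any order on these numbers.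

Compound 4, `N#CC1=C(N)OC(c2c[nH]c3ccccc23)=C(C#N)C1c1ccccc1Cl`, differs from compound 3 by 2-chlorophenyl in place of 4-methoxyphenyl on a saturated ring carbon. The measured steps that bear on this are a 1.1-fold lower number from compound 1 to compound 2 (0.02 log units; within the scatter), a 1.1-fold lower number from compound 1 to compound 3 (0.04 log units; within the scatter) and a 1.0-fold lower number from compound 2 to compound 3 (0.02 log units; within the scatter): each exchanges one group on the phenyl ring attached to the shared core, and each stays within the scatter. None of them exchanges a 4-methoxyphenyl for a 2-chlorophenyl, so the change to compound 4 is only partly covered by what has been measured. On the evidence so far, no step beyond the scatter in this assay is expected, which as a step from compound 3 means a 1.0-fold higher number from compound 3 to compound 4 (0.01 log units; within the scatter). Compound 4 is therefore estimated at 880 ug/mL, with a range from 450 ug/mL to 1700 ug/mL.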

Compound 4, half-maximal inhibitory concentration: > 1000 ug/mL
Compound 4 was reported as a limit; the forecaster's own chance of this, stated with the estimate: 5%; at least 1.1-fold (0.05 log units) between middle value and limit.
By their numbers in this assay, from the lowest: compounds 3, 2 and 1 (each within the scatter of the next). At a limit, above all of these: compound 4.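

In this assay compound 4 is reported only as a limit, > 1000 ug/mL. With 2-chlorophenyl on the saturated ring carbon, the series loses a measured number for the first time, yet the floors of the steps, an at least 1.1-fold higher number from compound 3 to compound 4 (0.06 log units; that floor lies within the scatter), an at least 1.1-fold higher number from compound 2 to compound 4 (0.04 log units; that floor lies within the scatter) and an at least 1.0-fold higher number from compound 1 to compound 4 (0.02 log units; that floor lies within the scatter), all lie within the scatter, so this change is not shown to exceed the scatter and its true size stays unbounded. The single compound at a limit is also the only one carrying 2-chlorophenyl rather than 4-bromophenyl, 4-(dimethylamino)phenyl or 4-methoxyphenyl: the limit of > 1000 ug/mL in this assay, at which 1 of the 4 values shown sits.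

Open, from the compounds shown here alone, is how far compound 4 lies past its limit, and whether the chlorine itself or its place on the phenyl ring goes with that limit. Also open, going by these compounds, is how a carboxylic acid or a primary amine on that phenyl ring would read in this assay.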